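The source may report more compounds than this note shows. Statements on the series, on what has been measured and on what is new or still open speak of the compounds shown alone.

In a functional assay on B16 cells (Mus musculus), read by spectrophotometry, with a stated time of 3 days (on this read-out higher numbers stand for weaker inhibition and lower numbers for stronger inhibition), compound 1 (`CNC(=S)N/N=C/c1cccc2ccccc12`) gives 2000 nM and compound 2 (`CN(/N=C/c1cccc2ccccc12)C(N)=S`) gives 1600 nM, so the two values lie within the scatter of each other. Among the measured compounds shown here, the only measured step, a 1.3-fold lower number from compound 1 to compound 2 (0.10 log units; within the scatter), exchanges one sulfur-bearing group for another on a double-bonded nitrogen. Compound 3 (`NC(=O)N/N=C/c1cccc2ccccc12`) changes that same place: a group of 4 heavy atoms (1 carbon, 2 nitrogen, 1 oxygen; no ring) in place of a group of 5 heavy atoms (2 carbon, 2 nitrogen, 1 sulfur; no ring), on a double-bonded nitrogen. Here the ureido enters and the sulfur leaves with the outgoing group. For the measured compounds named here, no measured step replaces sulfur with oxygen, so the size of this change is not measured directly, and the step from compound 1 gives only a weak guide. A moderately higher number is expected, with low confidence in its size. The expected change is a 3.8-fold higher number from compound 2 to compound 3 (0.57 log units; beyond the scatter). For compound 3 the estimate is 6000 nM, expected to fall between 1500 nM and 25000 nM.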

Compound 3, half-maximal inhibitory concentration: > 100000 nM
Compound 3: a limit, no number; the forecaster's own chance of this, stated with the estimate: 10%; at least 16-fold (1.22 log units) between middle value and limit.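

In this assay compound 3 gives a limit and not a number: the limit of > 100000 nM in this assay, at which 1 of the 3 values shown sits.

Both steps to the ureido are large, an at least 62-fold higher number from compound 2 to compound 3 (1.79 log units; beyond the scatter) and an at least 50-fold higher number from compound 1 to compound 3 (1.69 log units; beyond the scatter), while the exchange between the two sulfur-bearing groups, a 1.3-fold lower number from compound 1 to compound 2 (0.10 log units; within the scatter), stays within the scatter. The place on a double-bonded nitrogen, which showed no measurable response in that first step, thus responds strongly to the change in which sulfur leaves and the ureido enters.

Going by these compounds, the full size of the step stays unknown, as compound 3 gives only a limit. The outgoing group also holds more carbon than the ureido, so the loss of sulfur and the loss of carbon remain unseparated; a methyl-bearing ureido would tell them apart.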